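Swapping Bromo for Acetamidomethyl on a Shared Core

A few compounds are considered here, and "the series" means these few. Any claim that something is new, unique, unknown or untested is made for them only; others in the source may bear on it.

Compound 1 `Oc1cccc2c1nc(-c1c(F)cccc1F)n2Cc1c(F)cccc1F`: > 100 uM (a limit of the assay)
Compound 2 `Fc1cccc(F)c1Cn1c(-c2c(F)cccc2F)nc2c(Br)cccc21`: 24.5 uM
Compound 3 `CN(C)c1cccc2c1nc(-c1c(F)cccc1F)n2Cc1c(F)cccc1F`: > 100 uM (a limit of the assay)

Three measured compounds share one core and differ only in the group on one aromatic carbon. In a toxicity assay on CCRF-CEM cells (Homo sapiens) for cytotoxicity (on this read-out higher numbers stand for lower toxicity in this test and lower numbers for higher toxicity in this test), compound 1 reaches only the limit of the assay, > 100 uM. Compound 3 likewise stops at the limit, > 100 uM. Compound 2 alone gives a real number, 24.5 uM, and so it is the most toxic of the three in this test.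

Compound 4 `CC(=O)NCc1cccc2c1nc(-c1c(F)cccc1F)n2Cc1c(F)cccc1F` has not yet been measured. It differs from compound 2 as follows:
acetamidomethyl in place of bromo on an aromatic carbon

Among the measured compounds shown here, two measured steps bear on this change, since both leave or arrive at bromo: an at least 4.0-fold lower number from compound 1 to compound 2 (0.61 log units; beyond the scatter) and an at least 4.0-fold higher number from compound 2 to compound 3 (0.61 log units; beyond the scatter). In both, the compound without bromo sits at the limit (the limit of > 100 uM in this assay, at which 2 of the 3 values shown sit). By that evidence, replacing bromo with acetamidomethyl is expected to raise the number again, quite possibly back to the limit.

Compound 4 is therefore estimated at 100 uM, within a range of 40 uM to 300 uM, an expected step of a 4.1-fold higher number from compound 2 to compound 4 (0.61 log units; beyond the scatter).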

Compound 4, half-maximal toxic concentration: 20.8 uM
Beside the measured number, compound 4's estimate is 4.8-fold (0.68 log units) above it; measured number outside the range, below it.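

Among the compounds shown here, until now, bromo was the only group on this aromatic carbon that gave a real number in this assay, and compound 4 shows that it is not alone, with a 1.2-fold lower number from compound 2 to compound 4 (0.07 log units; within the scatter), so acetamidomethyl and bromo cannot be told apart here even though the two groups differ in size and in their hydrogen-bond donors and acceptors. Set against hydroxy and dimethylamino, acetamidomethyl stands apart much as bromo does, with an at least 4.8-fold lower number from compound 3 to compound 4 (0.68 log units; beyond the scatter) and an at least 4.8-fold lower number from compound 1 to compound 4 (0.68 log units; beyond the scatter). These two steps give only a smallest possible size, since each one starts from a limit: the limit of > 100 uM in this assay, at which 2 of the 4 values shown sit.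

The compounds shown do not reveal which part of acetamidomethyl goes with the lower number, whether the amide hydrogen, the carbonyl or the chain that carries them. Going by these compounds, it also remains open whether an aminomethyl group, a carboxylic acid or a longer amide chain on this aromatic carbon would fall with bromo and acetamidomethyl or with hydroxy and dimethylamino.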